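Propyl to tert-butyl on the amide carbonyl of compound 1

This account rests on a few compounds, and the source may have more. Where it says the series, first, only, none or still open, it means among the compounds named here.

Three sulfonate esters with a shared core carry different amide acyl groups and different substituents on the phenol ring. Compound 1 `CCCC(=O)Nc1ccc(S(=O)(=O)Oc2ccccc2C(C)C)cc1` gives the lowest number of the three in a functional assay on M21 cells (Homo sapiens) for antiproliferative activity, read by sulforhodamine B assay, with a stated time of 48 h (a higher number here means a weaker inhibitor, a lower number a stronger inhibitor), namely 6100 nM for compound 1. Compound 2 `CCCC(=O)Nc1ccc(S(=O)(=O)Oc2ccccc2I)cc1` gives 9000 nM in this assay, and compound 3 `CC(C)C(=O)Nc1ccc(S(=O)(=O)Oc2ccccc2I)cc1` gives 13000 nM; the gap from compound 1 to compound 2 is within the scatter, while the values of compound 1 and compound 3 lie apart by more than the scatter.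

Compound 4 `CC(C)c1ccccc1OS(=O)(=O)c1ccc(NC(=O)C(C)(C)C)cc1` differs from compound 1 by tert-butyl in place of propyl on a carbonyl carbon. For the measured compounds named here, the only measured step at the same place is a 1.4-fold higher number from compound 2 to compound 3 (0.16 log units; within the scatter), a change of similar kind and within the scatter; the step of a 1.5-fold higher number from compound 1 to compound 2 (0.17 log units; within the scatter) sits elsewhere and is also within the scatter. Growing the acyl chain further at the carbonyl carbon is therefore expected to give at most a small rise in the number, a 1.4-fold higher number from compound 1 to compound 4 (0.14 log units; within the scatter). For compound 4 the expected value in this assay is 8500 nM, with a range from 4000 nM to 18000 nM.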

Compound 4, half-maximal inhibitory concentration: 6200 nM
Estimate against measurement, compound 4: 1.4-fold (0.14 log units) above; low and high end bracket the measured number.
By their numbers in this assay, from the lowest: compounds 1, 4, 2 and 3 (each within the scatter of the next, the first and the last beyond it).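

Tert-butyl in place of propyl on a carbonyl carbon gives a 1.0-fold higher number from compound 1 to compound 4 (0.01 log units; within the scatter) in this assay, so this fully branched group, with isopropyl retained on the phenol ring, does not separate compound 4 from compound 1. For the compounds shown here, until now, the only reading at this carbonyl carbon was a 1.4-fold higher number from compound 2 to compound 3 (0.16 log units; within the scatter), taken with iodo on the phenol ring and with isopropyl as the entering group. The acyl group has now been changed with both phenol substituents, and neither step lies beyond the scatter, although two steps are a narrow basis for any rule about this position. No supporting data are available to explain this flat reading.

Still open, as far as these compounds go, is how a longer chain, such as octyl, or an acyl group carrying an amine or a carboxylic acid would read at this carbonyl carbon. Also open, from the compounds shown here alone, is whether tert-butyl reads the same way with iodo on the phenol ring.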